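The source may report more compounds than this note shows. Statements on the series, on what has been measured and on what is new or still open speak of the compounds shown alone.

Measured in a functional assay on NCI-H460 cells (Homo sapiens) for inhibition; on this read-out lower numbers stand for stronger inhibition of growth and higher numbers for weaker inhibition of growth:
- Compound 1 `Nc1ccc(-c2nc3cc(F)ccc3s2)cc1`: 870 nM
- Compound 2 `Cc1cc(-c2nc3ccc(F)cc3s2)ccc1N`: 100 nM
- Compound 3 `Nc1ccc(-c2nc3ccccc3s2)cc1F`: < 10 nM, a limit of the assay

Compound 1, at 870 nM, has the higher of the two actual numbers, and compound 2, at 100 nM, lies lower by a gap beyond the usual scatter. Compound 3 is reported only as a limit of the assay, < 10 nM.

The next compound is compound 4 `Nc1ccc(-c2nc3cc(F)ccc3s2)cc1Br`, which keeps the core of compound 1 and carries bromo in place of hydrogen on an aromatic carbon, ortho to an amino group (bromo in place of hydrogen on an aromatic carbon). For the measured compounds named here, no measured pair isolates this change, so any expectation rests on indirect comparison. Compound 2, at 100 nM, has a methyl group on that ring ortho to its amino group, though it also differs from compound 1 elsewhere. Compound 3 has a fluoro group ortho to its amino group and also differs elsewhere, and its limit is < 10 nM. Compound 1 lacks any such group and has the higher number, at 870 nM.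

The expected step of a 44-fold lower number from compound 1 to compound 4 (1.64 log units; beyond the scatter) is therefore a fall beyond the scatter, towards stronger inhibition of growth. For compound 4 the expected value is 20 nM, with an estimated range from 3 nM to 150 nM.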

Compound 4, concentration for 50% growth inhibition: 110 nM
Estimate against measurement, compound 4: 5.5-fold (0.74 log units) below, within the range that was stated.
By their numbers in this assay, from the lowest: compounds 2 and 4 (each within the scatter of the next); then compound 1. At a limit, below all of these: compound 3.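

In this assay, compounds 1 and 4 form the only pair shown that differs in one place, so the effect of this change can now be read directly: bromo in place of hydrogen on an aromatic carbon, ortho to an amino group, gives a 7.9-fold lower number from compound 1 to compound 4 (0.90 log units; beyond the scatter). The earlier compounds shown here could only hint at this, as each carrying a group at this position also differed from compound 1 elsewhere. The pair shows that this position accepts a group as large as bromo and that, on the core of compound 1, the change moves the read-out towards stronger inhibition of growth by a modest step beyond the scatter, though it does not show how the bromo brings this about.

With only bromo shown on the core of compound 1, it remains open whether a chloro group, an amine or a carboxylic acid at this position would give a similar step, a larger one or the opposite. Compound 3 is reported only as a limit, so its number stays unknown: the limit of < 10 nM in this assay, at which 1 of the 4 values shown sits.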